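This account rests on a few compounds, and the source may have more. Where it says the series, first, only, none or still open, it means among the compounds named here.

Of the compounds shown here, three that share one core have been measured in a functional assay on HCT-116 cells (Homo sapiens) for antiproliferative activity, read by MTT assay; a lower number here means a stronger inhibitor, a higher number a weaker inhibitor. Compound 1 `CNC1=CC(=O)c2ccccc2C1=O` gives 55700 nM. Compound 2 `O=C1C=C(N2CCCC2)C(=O)c2ccccc21` gives 159000 nM. Compound 3 `O=C1C=C(NCCO)C(=O)c2ccccc21` gives 70300 nM. On these numbers compound 3 stands second highest of the three: its nearest neighbour is compound 1, with a 1.3-fold higher number from compound 1 to compound 3 (0.10 log units; within the scatter), and its furthest is compound 2, with a 2.3-fold lower number from compound 2 to compound 3 (0.35 log units; beyond the scatter). The step of a 2.9-fold higher number from compound 1 to compound 2 (0.46 log units; beyond the scatter) shows how far the choice of group on the amine nitrogen moved the number among the measured compounds.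

Compound 4 `NCCCNC1=CC(=O)c2ccccc2C1=O` differs from compound 3 by aminomethyl in place of hydroxy on a saturated chain carbon, two bonds along the chain from an amine nitrogen. Going by the values given here, the steps that bear on this change are those that alter what sits on the amine nitrogen. Of these, a 1.3-fold higher number from compound 1 to compound 3 (0.10 log units; within the scatter) is within the scatter, while a 2.9-fold higher number from compound 1 to compound 2 (0.46 log units; beyond the scatter) and a 2.3-fold lower number from compound 2 to compound 3 (0.35 log units; beyond the scatter) are modest. A change of this kind on the chain is accordingly expected to move the number in this assay little, quite possibly not beyond the scatter. Compound 4 is therefore estimated to give 60000 nM, within a range from 25000 nM to 150000 nM, which means an expected step of a 1.2-fold lower number from compound 3 to compound 4 (0.07 log units; within the scatter).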

Compound 4, half-maximal inhibitory concentration: 59600 nM
Compound 4: middle estimate off by 1.0-fold (0.00 log units), on the high side; measured number inside the range.
By their numbers in this assay, from the lowest: compounds 1, 4 and 3 (each within the scatter of the next); then compound 2.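

In this assay, putting aminomethyl in place of hydroxy on the chain, which turns (2-hydroxyethyl)amino into (3-aminopropyl)amino, gives a result that cannot be told apart from repeat-measurement noise, with a 1.2-fold lower number from compound 3 to compound 4 (0.07 log units; within the scatter). The earlier compounds shown here showed only that a hydroxy-ended chain could stand in for the small methylamino group, whereas this result shows that a longer chain ending in an amine can do so too, since a 1.1-fold higher number from compound 1 to compound 4 (0.03 log units; within the scatter) also lies within the scatter. The gap to the pyrrolidin-1-yl compound persists with the new chain, at a 2.7-fold lower number from compound 2 to compound 4 (0.43 log units; beyond the scatter), so among these four compounds, compound 2 alone stands apart from the others.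

From the compounds shown here alone, it remains open whether this tolerance extends to other chain ends at the same place, such as a carboxylic acid, a dimethylamino group or an amide, or to a chain longer than 3-aminopropyl. Nothing shown here offers any measured explanation for how little the chain end changes the number.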